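Nitro for trifluoromethyl on the aryl piperazine

This account rests on a few compounds, and the source may have more. Where it says the series, first, only, none or still open, it means among the compounds named here.

Measured so far:
compound 1 `COc1cccc2c1N(CCCN1CCN(c3cccc(Cl)c3)CC1)C(=O)CC2` gives 600 nM in an assay on cell membranes for binding affinity to Sigma non-opioid intracellular receptor 1 (Rattus norvegicus); a higher number here means a weaker inhibitor, a lower number a stronger inhibitor
compound 2 `COc1cccc2c1CCC(=O)N2CCCN1CCN(c2cccc(C(F)(F)F)c2)CC1` gives 490 nM in this assay

Compound 2 has the lowest of the two numbers in this assay, but its nearest neighbour, compound 1, is within the scatter of it, so the two show no real difference.

Compound 3 `COc1cccc2c1CCC(=O)N2CCCN1CCN(c2cccc([N+](=O)[O-])c2)CC1` is not yet measured. It differs from compound 2 in one place: nitro in place of trifluoromethyl on an aromatic carbon.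

Within the data shown here, no step between measured compounds covers this change. Both measured compounds carry different groups at this position and give numbers within the scatter of each other. On that basis the step from compound 2 to compound 3 in this assay is expected to be small, in no firm direction, and likely not beyond the scatter: a 1.0-fold higher number from compound 2 to compound 3 (0.01 log units; within the scatter). Compound 3 is therefore estimated at 500 nM, with a range of 150 nM to 1600 nM.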

Compound 3, half-maximal inhibitory concentration: 870 nM
Estimate against measurement, compound 3: 1.7-fold (0.24 log units) below; measured number inside the range.
By their numbers in this assay, from the lowest: compounds 2, 1 and 3 (each within the scatter of the next).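

Nitro in place of trifluoromethyl on the aromatic carbon gives, in this assay, a 1.8-fold higher number from compound 2 to compound 3 (0.25 log units; within the scatter). Among these compounds, this is the first step read directly at this position, and it shows that exchanging trifluoromethyl, with no hydrogen-bond acceptors, for nitro, with two, leaves the result within the scatter, so the two groups cannot be told apart here. No evidence is available that bears on this result.

The compounds shown leave open whether a group of another kind on this aromatic carbon, such as an amine or a carboxylic acid, would give a step beyond the scatter. They also leave open whether a plain phenyl, with only hydrogen at this place, would differ from the 3-nitrophenyl of compound 3 in this assay.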